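From 4-ethylphenyl to 4-cyanophenyl on a shared core

A few compounds are considered here, and "the series" means these few. Any claim that something is new, unique, unknown or untested is made for them only; others in the source may bear on it.

In a functional assay on HepG2 cells (Homo sapiens) for inhibition, read by MTT assay, with a stated time of 48 h (on this read-out higher numbers stand for weaker inhibition and lower numbers for stronger inhibition), compound 1 (`CCc1ccc(-c2nc3ccccn3c2Sc2ccccc2)cc1`) gives 50200 nM and sits at the high end of the numbers in hand. Compound 3 (`c1ccc(Sc2c(-c3ccccc3)nc3ccc(-c4ccccc4)cn23)cc1`) shares that end at 47800 nM and lies within the scatter of compound 1, but it differs from compound 1 in more than one place and so offers no clean comparison. Compound 2 (`C(=C/c1nc2ccccn2c1Sc1ccccc1)\c1ccccc1`) stands apart at 8800 nM and carries 2-phenylethenyl in place of 4-ethylphenyl.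

The next case is compound 4 (`N#Cc1ccc(-c2nc3ccccn3c2Sc2ccccc2)cc1`), with cyano in place of ethyl on an aromatic carbon, para to a large group (cyano in place of ethyl on an aromatic carbon). The same difference reads as 4-ethylphenyl to 4-cyanophenyl.

Within the data shown here, only one measured step bears on this position, and it replaces the whole 4-ethylphenyl group: a 5.7-fold lower number from compound 1 to compound 2 (0.76 log units; beyond the scatter) is what that larger replacement gave. Among the measured compounds shown here, no measured step isolates cyano, and compound 4 keeps the phenyl ring, so a smaller shift is expected in this assay and none beyond the scatter. The expected step is a 1.4-fold lower number from compound 1 to compound 4 (0.16 log units; within the scatter) on this estimate. For compound 4 the estimated value is 35000 nM with an expected range from 12000 nM to 90000 nM in this read-out.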

Compound 4, half-maximal inhibitory concentration: 15700 nM
Estimate against measurement, compound 4: 2.2-fold (0.35 log units) above; measured number inside the range.
By their numbers in this assay, from the lowest: compounds 2 and 4 (each within the scatter of the next); then compounds 3 and 1 (each within the scatter of the next).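

In this assay, among these compounds, the earlier compounds showed a shift at this position only when the whole 4-ethylphenyl group was replaced, whereas here the phenyl ring stays and only the group on its aromatic carbon, para to a large group, is exchanged, giving a 3.2-fold lower number from compound 1 to compound 4 (0.50 log units; beyond the scatter) for cyano in place of ethyl. This small exchange brings the series to the level of the larger replacement: the comparison of the two gives a 1.8-fold higher number from compound 2 to compound 4 (0.25 log units; within the scatter), so 4-cyanophenyl and 2-phenylethenyl cannot be told apart on this read-out, and a change in the phenyl ring is enough to produce a step beyond the scatter without removing that ring. Nothing at hand speaks to the reason for this step.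

With only ethyl and cyano shown on this ring, the compounds leave open whether an amine, a carboxylic acid or a chain longer than ethyl in the same place would stay with compound 1, stay with compound 4 or fall elsewhere. They also leave open whether the exchange of ethyl for cyano would give a similar step on another core, such as the core of compound 3.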